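Adding a methyl to the benzyl arm: a small step

The compounds below may be only part of what the source reports. "The series", "measured", "known", "first", "only" and "open" are said of these compounds alone.

Three close relatives of one scaffold have been tested in a functional assay on HL-60 cells (Homo sapiens) for inhibition, read by CCK-8 assay, with a stated time of 48 h, tested at 20 uM; on this read-out lower numbers stand for less inhibition of growth and higher numbers for more inhibition of growth at the one concentration tested. Compound 1 `Cc1ccc(S(=O)(=O)Oc2ccccc2/C=C(\C#N)C(=O)Nc2nnc(Cc3ccccc3)s2)cc1` gives 16%. Compound 2 `N#C/C(=C\c1ccccc1OS(=O)(=O)c1ccccc1[N+](=O)[O-])C(=O)Nc1nnc(Cc2ccccc2)s1` gives 12%. Compound 3 `N#C/C(=C\c1ccccc1OS(=O)(=O)c1ccc(F)cc1)C(=O)Nc1nnc(Cc2ccccc2)s1` gives 22%, the highest of the three numbers, though its separation from the others is not beyond the scatter: a number 6 percentage points higher from compound 1 to compound 3 (within the scatter) and a number 10 percentage points higher from compound 2 to compound 3 (within the scatter), while a number 4 percentage points lower from compound 1 to compound 2 (within the scatter). All three measured differences sit on the aryl group attached to the sulfonyl sulfur, and none of them moved this assay beyond its noise.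

Compound 4 `Cc1ccc(Cc2nnc(NC(=O)/C(C#N)=C/c3ccccc3OS(=O)(=O)c3ccc(F)cc3)s2)cc1` differs from compound 3 elsewhere: methyl in place of hydrogen on an aromatic carbon, on the ring of the benzyl group, so that benzyl becomes 4-methylbenzyl. Within the data shown here, no measured step touches this part of the molecule, so there is nothing direct to lean on. What the measured steps do show is that small changes on the aromatic periphery of this scaffold have stayed within the scatter. On that basis the change to compound 4 is expected to give a step of no change at the digits printed from compound 3 to compound 4 (within the scatter), that is, no step beyond the scatter. Compound 4 is therefore estimated at 22% in this assay, with a range from 8% to 36%.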

Compound 4, percent growth inhibition at one concentration: 11%
For compound 4 the middle estimate is 11 percentage points above the measured one; low and high end bracket the measured number.
By their numbers in this assay, from the lowest: compounds 4, 2, 1 and 3 (each within the scatter of the next, the first and the last beyond it).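

Among these compounds, the benzyl arm is the part of the molecule that no earlier step touched, and it proves sensitive: in this assay, changing benzyl to 4-methylbenzyl, with a methyl on an aromatic carbon para to a large group, gives a number 11 percentage points lower from compound 3 to compound 4 (beyond the scatter) for the addition of just 1 carbon. Among the compounds shown here, this is the only step in the set that lies beyond the scatter, whereas the three steps among compounds 1, 2 and 3, all on the aryl group on the sulfonyl sulfur, stayed within it, so the periphery of this scaffold cannot be treated as uniformly tolerant of small changes. Nothing in the data shown explains why this added methyl goes with a lower number.

As far as these compounds go, it remains open whether this drop belongs to the methyl itself or would follow any group on that ring carbon, such as a chlorine, a methoxy, a hydroxyl or an amine, or a longer chain such as ethyl. Also open, from the compounds shown here alone, is whether the same methyl would give a similar step with the 4-methylphenyl or 2-nitrophenyl group on the sulfonyl sulfur in place of 4-fluorophenyl.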